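The source may hold more compounds than are shown below. What is called first, only, known or untested is meant among the compounds shown, and "the series" means these compounds.

Among the measured compounds shown here, compound 2 `Cc1ccc(-n2nc(C(=O)Nc3ccc(Oc4ncnc5[nH]ccc45)c(F)c3)c(C)cc2=O)cc1` is one of two compounds measured in a functional assay on HepG2 cells (Homo sapiens) for cytotoxicity, read by MTT assay, with a stated time of 72 h; a higher number here means a weaker inhibitor, a lower number a stronger inhibitor. In this assay compound 2 gives 18800 nM, the highest of the two numbers. Its nearest neighbour is compound 1 `Cc1cc(=O)n(-c2cccc(C(F)(F)F)c2)nc1C(=O)Nc1ccc(Oc2ncnc3[nH]ccc23)cc1`; in this assay compound 1 gives 9470 nM, a gap that lies within the scatter of repeated measurement. Compound 3 `Cc1cc(=O)n(-c2cccc(C(F)(F)F)c2)nc1C(=O)Nc1ccc(Oc2ncnc3[nH]ccc23)c(F)c1` differs from compound 2 in one place: 3-(trifluoromethyl)phenyl in place of 4-methylphenyl on an aromatic nitrogen. For the measured compounds named here, no measured pair shows this change on its own, so its effect has not been observed directly. Compound 3 carries the same 3-(trifluoromethyl)phenyl group as compound 1, and no step beyond the scatter is expected in either direction, because compound 1 gives 9470 nM and that number sits within the scatter of compound 2. Compound 3 is therefore expected to give about 11000 nM in this assay, within a range from 4000 nM to 30000 nM, which means an expected step of a 1.7-fold lower number from compound 2 to compound 3 (0.23 log units; within the scatter).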

Compound 3, half-maximal inhibitory concentration: 26300 nM
Estimate against measurement, compound 3: 2.4-fold (0.38 log units) below; low and high end bracket the measured number.
By their numbers in this assay, from the lowest: compounds 1, 2 and 3 (each within the scatter of the next, the first and the last beyond it).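

In this assay, 3-(trifluoromethyl)phenyl in place of 4-methylphenyl on the aromatic nitrogen gives a 1.4-fold higher number from compound 2 to compound 3 (0.15 log units; within the scatter) in the presence of the fluoro group, so this exchange of aryl groups is not told apart from the scatter. The fluoro in place of hydrogen on an aromatic carbon gives a 2.8-fold higher number from compound 1 to compound 3 (0.44 log units; beyond the scatter) with 3-(trifluoromethyl)phenyl held constant, a modest step and the only one of the two that lies beyond the scatter. No measurement shown here accounts for either step.

The compounds shown leave open whether the fluoro step also holds with 4-methylphenyl on the aromatic nitrogen. They also leave open what a chloro or a methoxy group at the fluoro position, or a carboxylic acid on the phenyl group, would do in this series.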